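The compounds below may be only part of what the source reports. "The series", "measured", "known", "first", "only" and "open" are said of these compounds alone.

Three compounds sharing one core have been examined in a functional assay on CHO cells for agonist activity at Alpha-1D adrenergic receptor (Homo sapiens), read by FLIPR and calcium flux (a lower number here means that less compound is needed, a higher number that more compound is needed for the effect), and a fourth awaits testing. Compound 1 `COc1c(C)ccc2c1CCC2c1ncc[nH]1` carries a methoxy group and a methyl on its aromatic ring. In this assay compound 1 gives > 10000 nM, which is a limit of the assay rather than a number. Compound 2 `CS(=O)(=O)Nc1cccc2c1CCC2c1ncc[nH]1` bears a methanesulfonamido group instead. In this assay compound 2 gives > 10000 nM, again a limit. Compound 3 `CNC(=O)c1cccc2c1CCC2c1ncc[nH]1` carries a methylcarbamoyl group in that place. In this assay compound 3 gives > 10000 nM, once more a limit. Compound 2 thus stands at a limit only, and no number separates it from the other two: the limit of > 10000 nM in this assay, at which 3 of the 3 values shown sit. For the measured compounds named here, the single step among the measured compounds, a step that the two limits leave unreadable from compound 2 to compound 3, is consequently of unreadable size.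

Compound 4 `Cc1ccc2c(c1NS(C)(=O)=O)CCC2c1ncc[nH]1` differs from compound 2 by methyl in place of hydrogen on an aromatic carbon. Going by the values given here, no measured step shows how such a methyl alters activity here, and the step from compound 2 to compound 3 offers no readable size. The expectation for compound 4 is therefore that its value in this assay stays near the limit. Compound 4 is estimated at 20000 nM, with a range expected from 5000 nM to 100000 nM. The step that the limit leaves unreadable from compound 2 to compound 4 is expected to be none beyond the scatter.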

Compound 4, half-maximal effective concentration: > 10000 nM
Compound 4 gave a limit, no number; the forecaster's own chance of this, stated with the estimate: 80%; the middle value does not contradict the limit.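

In this assay compound 4 gives > 10000 nM, a limit and not a number. No new step to compound 4 from compound 1 or compound 2 can be read, since all of them stand at one limit: the limit of > 10000 nM in this assay, at which 4 of the 4 values shown sit.

The compounds shown leave open whether any group on the shared core brings a measurable effect in this assay, and what methyl in place of hydrogen does to it.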